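The compounds below may be only part of what the source reports. "The series", "measured", "known", "first", "only" and "open" are said of these compounds alone.

Measured so far in an assay on lysate for inhibition of phosphatidylcholine:ceramide cholinephosphotransferase 2 (Homo sapiens), read by HPLC, with stated times of 30 min and 2 h; a higher number here means a weaker inhibitor, a lower number a stronger inhibitor:
compound 1 `O=C(Nc1cccnc1)c1ccccc1OCc1cccc(Cl)c1`: 1400 nM
compound 2 `O=C(Nc1cccnc1)c1ccccc1OCc1cccc(Cl)c1F`: 3100 nM

Of these two, compound 2 carries the higher number, so it is the weaker inhibitor of the pair. Among the compounds with values here, the only step measured, a 2.2-fold higher number from compound 1 to compound 2 (0.35 log units; beyond the scatter), came from putting fluoro in place of hydrogen on an aromatic carbon, a modest move toward weaker inhibition.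

Compound 3 `Cc1c(Cl)cccc1COc1ccccc1C(=O)Nc1cccnc1` is the next compound to be measured. It differs from compound 2 by methyl in place of fluoro on an aromatic carbon. Within the data shown here, the single measured step bears on this only loosely: it shows that changing the group on this carbon of the chlorophenyl ring shifts the number by a modest amount, and nothing beyond that. Among the measured compounds shown here, no measured step tells what a methyl at this position does, so the direction is open and a modest shift either way, or none beyond the scatter, fits the evidence.

Compound 3 is therefore expected to give about 2500 nM in this assay, most likely between 800 nM and 8000 nM. The estimated step is a 1.2-fold lower number from compound 2 to compound 3 (0.09 log units; within the scatter).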

Compound 3, half-maximal inhibitory concentration: 3800 nM
Compound 3: the middle estimate sits 1.5-fold (0.18 log units) below what was measured; low and high end bracket the measured number.
By their numbers in this assay, from the lowest: compound 1; then compounds 2 and 3 (each within the scatter of the next).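

In this assay, methyl in place of fluoro on this carbon, ortho to a chloro group, gives a 1.2-fold higher number from compound 2 to compound 3 (0.09 log units; within the scatter), so the assay does not separate these two groups here, even though one is a halogen and the other a small carbon group. Methyl in place of hydrogen on the same carbon gives a 2.7-fold higher number from compound 1 to compound 3 (0.43 log units; beyond the scatter) and this modest change points the same way as the earlier fluoro step, which leaves hydrogen as the best of the three groups seen at this position and compound 1 as the strongest inhibitor of the three. The data shown offer no measured explanation for either of these results.

As far as these compounds go, three small groups on one carbon cannot show how much room for change this position has, so it remains open whether a hydroxyl, an amine or a longer chain such as propyl would follow the same trend or depart from it. From the compounds shown here alone, it also remains open whether methyl or fluoro would have the same effect in a compound without the chloro group.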